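From Ester to Carboxy Group on the Ring Nitrogen

A few compounds are considered here, and "the series" means these few. Any claim that something is new, unique, unknown or untested is made for them only; others in the source may bear on it.

Compound 1 `COc1cc(OC)c(/C=C/S(=O)(=O)Cc2ccc(F)c(N)c2)c(OC)c1` and compound 2 `COC(=O)CNc1cc(CS(=O)(=O)/C=C/c2c(OC)cc(OC)cc2OC)ccc1OC` were both tested in a functional assay on K562 cells (Homo sapiens) for cytotoxicity, read by trypan blue exclusion, with a stated time of 96 h; a lower number here means a stronger inhibitor, a higher number a weaker inhibitor. Compound 1 gives 2500 nM, while compound 2 gives 100 nM, the lowest of the two numbers and a gap beyond the scatter. Compound 3 `COc1cc(OC)c(/C=C/S(=O)(=O)Cc2ccc(OC)c(NC(C(=O)O)c3ccc(Br)cc3)c2)c(OC)c1` differs from compound 2 by a single change: (4-bromophenyl)(carboxy)methyl in place of (methoxycarbonyl)methyl on a nitrogen on an aromatic ring. Among the measured compounds shown here, no measured step of this kind exists among the tested compounds, so one can only expect a modest rise in number, roughly a 2.5-fold higher number from compound 2 to compound 3 (0.40 log units; beyond the scatter). Compound 3 is accordingly estimated at 250 nM, within a range from 50 nM to 1500 nM.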

Compound 3, half-maximal inhibitory concentration: 200 nM
The estimate for compound 3 lay 1.3-fold (0.10 log units) above the measured number; the range from low to high includes it.
By their numbers in this assay, from the lowest: compounds 2 and 3 (each within the scatter of the next); then compound 1.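

In this assay the exchange of (methoxycarbonyl)methyl for (4-bromophenyl)(carboxy)methyl on a nitrogen on an aromatic ring gives a 2.0-fold higher number from compound 2 to compound 3 (0.30 log units; within the scatter) and leaves the two compounds indistinguishable. This position thus accepts the larger group, with its added aromatic ring and hydrogen-bond donor, without a step beyond the scatter. No measurement shown here explains this result.

As far as these compounds go, the carboxylic acid and the 4-bromophenyl ring enter together, so their separate contributions stay open. From the compounds shown here alone, it also remains open whether a methyl ester of the acid in compound 3, or an unsubstituted phenyl ring in place of the 4-bromophenyl ring, would give a similar number.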